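Ring Size Change on a Shared Core: Cytotoxicity Outlook

This account rests on a few compounds, and the source may have more. Where it says the series, first, only, none or still open, it means among the compounds named here.

Compound 1 `Cc1ccc2c(NCc3ccc(NC(=O)C4CCN(Cc5ccccc5)CC4)cc3)nc(N3CCC3)nc2c1` — > 8500 nM
Compound 2 `Cc1ccc2c(NCc3ccc(NC(=O)C4CCN(C(=O)OC(C)(C)C)CC4)cc3)nc(N(C)C)nc2c1` — > 4820 nM

In a functional assay on SV5A8 cells (Homo sapiens) for cytotoxicity (on this read-out higher numbers stand for weaker inhibition and lower numbers for stronger inhibition), compound 1 gives > 8500 nM, which is a limit of the assay and not a number. Compound 2 also gives only a limit, > 4820 nM. Both values shown are limits, so compound 1 cannot be placed against any measured number. Compound 3 `Cc1ccc2c(NCc3ccc(NC(=O)C4CCN(Cc5ccccc5)CC4)cc3)nc(N3CCCC3)nc2c1` carries pyrrolidin-1-yl in place of azetidin-1-yl on an aromatic carbon. Within the data shown here, with no measured step to lean on, no change beyond the scatter is expected, and compound 3 is estimated at 10000 nM within 3000 nM to 30000 nM. The expected step is a step that the limit leaves unreadable from compound 1 to compound 3.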

Compound 3, half-maximal inhibitory concentration: > 7790 nM
Compound 3 gave a limit, no number (the forecaster's own chance of this, stated with the estimate: 80%); the middle value does not contradict the limit.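

Compound 1 and compound 3 each give only a limit of the assay, not a number, so no step can be read between them. As far as these compounds go, whether pyrrolidin-1-yl and azetidin-1-yl differ in cytotoxicity on the shared core stays open.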